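Replacing pyrrolidine on the benzylic carbon of the core

A few compounds are considered here, and "the series" means these few. Any claim that something is new, unique, unknown or untested is made for them only; others in the source may bear on it.

Compound 3 `N#Cc1cccc(-c2nc(N)c3cc(CN4CCCC4)sc3n2)c1` gives 130 nM in an assay on CHO-K1 cells for antagonist activity at adenosine receptor A1 (Homo sapiens), read by a beta-galactosidase reporter, with stated times of 15 min and 6 h (on this read-out higher numbers stand for weaker inhibition and lower numbers for stronger inhibition), the lowest of the three numbers measured. Compound 1 `N#Cc1cccc(-c2nc(N)c3cc(CN4CC=CC4)sc3n2)c1` gives 2070 nM and compound 2 `N#Cc1cccc(-c2nc(N)c3cc(CN4CCC(F)CC4)sc3n2)c1` gives 2950 nM; the pair differs only within the scatter, a 1.4-fold higher number from compound 1 to compound 2 (0.15 log units; within the scatter). Compound 4 `C[C@@H]1CN(Cc2cc3c(N)nc(-c4cccc(C#N)c4)nc3s2)C[C@H](C)O1` carries 2,6-dimethylmorpholin-4-yl in place of pyrrolidin-1-yl on a saturated chain carbon bound to an aromatic carbon, the change read one bond further out being (pyrrolidin-1-yl)methyl to (2,6-dimethylmorpholin-4-yl)methyl. Among the compounds with values here, two measured steps bear on this position, both large and both in favour of pyrrolidin-1-yl: a 16-fold lower number from compound 1 to compound 3 (1.20 log units; beyond the scatter) and a 23-fold lower number from compound 2 to compound 3 (1.36 log units; beyond the scatter). Every departure from pyrrolidin-1-yl seen so far has cost potency, so a higher number is expected for compound 4, the estimated step being a 12-fold higher number from compound 3 to compound 4 (1.06 log units; beyond the scatter). Compound 4 is accordingly estimated at 1500 nM, with a range from 400 nM to 6000 nM.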

Compound 4, inhibition constant: 1070 nM
Compound 4: the middle estimate sits 1.4-fold (0.15 log units) above what was measured, within the range that was stated.
By their numbers in this assay, from the lowest: compound 3; then compounds 4, 1 and 2 (each within the scatter of the next, the first and the last beyond it).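

In this assay 2,6-dimethylmorpholin-4-yl is a third replacement that gives a higher number than pyrrolidin-1-yl (an 8.2-fold higher number from compound 3 to compound 4 (0.92 log units; beyond the scatter)), and none of the listed compounds goes against this. Within the data shown here, it also separates the replacements for the first time (a 2.8-fold lower number from compound 2 to compound 4 (0.44 log units; beyond the scatter)), although its step from the group in compound 1 stays within the scatter (a 1.9-fold lower number from compound 1 to compound 4 (0.29 log units; within the scatter)). No available evidence accounts for these differences.

The compounds shown leave open how piperidin-1-yl without fluorine or open-chain diethylamino would compare with pyrrolidin-1-yl on this carbon. Morpholin-4-yl without the two methyl groups also remains open.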